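The source may report more compounds than this note shows. Statements on the series, on what has been measured and on what is new or still open speak of the compounds shown alone.

Working notes on the series. Compound 1 `CCCc1nc(-c2ccccc2)c(CNCCN2CCN(c3cccc(OC)c3)CC2)o1` carries a 3-methoxyphenyl on the amine nitrogen in a ring. In an assay on HEK293 cells for inhibition of Voltage-dependent T-type calcium channel subunit alpha-1G (Homo sapiens), read by fluorescence, tested at 10 uM (a higher number here means more inhibition at the concentration tested (going by the name of the read-out), a lower number less inhibition), compound 1 gives 40.2%, the lowest of the three numbers shown, though both others sit within the scatter of it: compound 3 `CCCc1nc(-c2ccccc2)c(CNCCCN2CCN(c3ccccc3OC)CC2)o1` gives 41%, and compound 2 `CCCc1nc(-c2ccccc2)c(CNCCCN2CCN(c3ccccc3C(F)(F)F)CC2)o1` gives 45%. Among the measured compounds shown here, the single measured step between two of these, a number 4 percentage points lower from compound 2 to compound 3 (within the scatter), puts a methoxy in place of a trifluoromethyl on an aromatic carbon and stays within the scatter.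

Compound 4 `CCCc1nc(-c2ccccc2)c(CNCCN2CCN(c3ccccn3)CC2)o1` is the next entry: pyridin-2-yl in place of 3-methoxyphenyl on an amine nitrogen in a ring. For the measured compounds named here, no measured step exchanges the whole aromatic ring on this nitrogen; the only comparison at hand concerns a substituent on that ring and shows no movement beyond the scatter. With all three measured numbers sitting in a narrow band, the change to compound 4 is expected to leave it in that band, with no step beyond the scatter, so the expected step is a number 0.2 percentage points lower from compound 1 to compound 4 (within the scatter). Compound 4 is therefore estimated at 40%, with a range from 28% to 52%.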

Compound 4, a percentage reported as inhibition, at one concentration (the size of the read-out at that concentration, not a potency): 48.1%
Beside the measured number, compound 4's estimate is 8.1 percentage points below it; the range from low to high includes it.
By their numbers in this assay, from the lowest: compounds 1, 3, 2 and 4 (each within the scatter of the next).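

The exchange of the whole aromatic ring on the amine nitrogen in a ring, a carbon-only ring giving way to a ring with a hetero atom, gives in this assay a number 7.9 percentage points higher from compound 1 to compound 4 (within the scatter). Among the compounds shown here, the earlier step touched only a substituent on an aromatic ring, so this is the first sign that the ring itself can be exchanged at this position without a step beyond the scatter, even though the methoxy goes with it and the entering group has fewer heavy atoms. Nothing at hand gives a measured property of either group that bears on this step, and a step within the scatter offers little to explain in any case.

For the compounds shown here, the single step cannot separate the hetero atom in the ring from the loss of the methoxy, so a plain phenyl on this nitrogen would be the comparison that divides the two. As far as these compounds go, it also stays open whether pyrimidin-2-yl, a saturated ring such as cyclohexyl, or a carboxylic acid on the aromatic ring would move the number beyond the scatter at this position.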